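The compounds below may be only part of what the source reports. "The series", "measured", "known", "first", "only" and "open" are said of these compounds alone.

Compound 2, `CCN1C(=O)CSC1c1cccc(C(=O)NCCCCc2ccccc2)c1`, shows 0% in a functional assay on MG-63 cells (Homo sapiens) for inhibition, read by CCK-8 assay, with a stated time of 72 h, tested at 1 uM; on this read-out higher numbers stand for more inhibition at the one concentration tested (going by the name of the read-out) and lower numbers for less inhibition. On the numbers available it stands lowest; its nearest neighbour, compound 1, `Cc1cccc(N2C(=O)CSC2c2cccc(C(=O)NCCCCc3ccccc3)c2)c1`, gives 93% in this assay. The two differ in one place: the step of a number 93 percentage points lower from compound 1 to compound 2 (beyond the scatter) accompanies ethyl in place of 3-methylphenyl on an amide-type nitrogen in a ring.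

Compound 3, `COc1cc(F)ccc1N1C(=O)CSC1c1cccc(C(=O)NCCCCc2ccccc2)c1`, differs from compound 2 by 4-fluoro-2-methoxyphenyl in place of ethyl on an amide-type nitrogen in a ring. Going by the values given here, this change runs counter to the only measured step that bears on it: in compound 1 an aromatic ring sits on that nitrogen, in compound 2 an ethyl, and the fall from compound 1 to compound 2 was large and well beyond the scatter. Among the compounds with values here, compound 3 restores an aromatic ring at that position, though with different substituents from those of compound 1, and no measured pair shows what 4-fluoro-2-methoxyphenyl does there. A large rise is therefore expected, of about a number 75 percentage points higher from compound 2 to compound 3 (beyond the scatter), with the range widened because only compound 1 informs it. Compound 3 is estimated at 75% in this assay, within 30% to 98%.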

Compound 3, a percentage reported as inhibition, at one concentration (the size of the read-out at that concentration, not a potency): 92%
The estimate for compound 3 lay 17 percentage points below the measured number; the measured number falls inside the stated range.
By their numbers in this assay, from the lowest: compound 2; then compounds 3 and 1 (each within the scatter of the next).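

Placing 4-fluoro-2-methoxyphenyl on the amide-type nitrogen in place of ethyl gives a number 92 percentage points higher from compound 2 to compound 3 (beyond the scatter) and so repeats, with a second and differently substituted aromatic ring, the contrast that until now rested on compound 1 alone. In this assay the exchange of 3-methylphenyl for 4-fluoro-2-methoxyphenyl gives a number 1 percentage points lower from compound 1 to compound 3 (within the scatter) and so, at the one concentration tested, does not separate these two substituted phenyl groups, although they carry different substituents. Nothing in hand explains why ethyl and these two aromatic rings part so sharply at this position.

The three compounds do not show whether an aromatic ring as such is what matters here or simply a group larger than ethyl, and a cyclohexyl ring, a benzyl group or a longer chain such as n-hexyl on the same nitrogen would bear on that question. Unsubstituted phenyl and a pyridine ring also remain open, and a single-concentration read-out cannot show whether compound 1 and compound 3 would still match each other at lower concentrations.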